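Removing the ring methyl from compound 2

This account rests on a few compounds, and the source may have more. Where it says the series, first, only, none or still open, it means among the compounds named here.

In an assay on isolated protein for inhibition of long-chain fatty acid transport protein 1 (Homo sapiens), read by scintillation counting, with a stated time of 20 min (on this read-out lower numbers stand for stronger inhibition and higher numbers for weaker inhibition), compound 2 `CC1CCc2sc(NC(=O)CN3CCN(c4ccc(F)cc4)CC3)nc2C1` gives 26 nM, the lowest number of the three measured, and its gap to both neighbours lies beyond the scatter: compound 3 `O=C(CN1CCN(c2ccc(F)cc2)CC1)Nc1nc2c(s1)CCCCC2` gives 120 nM and compound 1 `O=C(CN1CCN(c2ccc(F)cc2)CC1)Nc1nc2c(o1)CCCC2` gives 180 nM in this assay. Compound 4 `O=C(CN1CCN(c2ccc(F)cc2)CC1)Nc1nc2c(s1)CCCC2` has not been measured in this assay. It differs from compound 2 in one place, (hydrogen in place of methyl on a saturated ring carbon), that is, hydrogen in place of methyl on a saturated ring carbon. Among the compounds with values here, no pair of measured compounds differs only by this change, so the size of the step must be estimated. Since the two compounds without a methyl on the saturated ring, compound 3 at 120 nM and compound 1 at 180 nM, both give higher numbers than compound 2, a moderate rise beyond the scatter, that is weaker inhibition, is expected for compound 4. For compound 4 in this assay a value of 70 nM is estimated, within a range of 25 nM to 200 nM. The expected step of a 2.7-fold higher number from compound 2 to compound 4 (0.43 log units; beyond the scatter) is thus toward weaker inhibition.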

Compound 4, half-maximal inhibitory concentration: 77 nM
Beside the measured number, compound 4's estimate is 1.1-fold (0.04 log units) below it; measured number inside the range.
By their numbers in this assay, from the lowest: compound 2; then compounds 4, 3 and 1 (each within the scatter of the next, the first and the last beyond it).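

In this assay, within the data shown here, a 3.0-fold higher number from compound 2 to compound 4 (0.47 log units; beyond the scatter) isolates this change for the first time, since no earlier pair differed only at this saturated ring carbon. The step is modest, yet it shows that this single methyl, one carbon on the six-membered non-aromatic ring, separates compound 2 from compound 4 by more than the scatter, with the rest of the structure unchanged. Nothing measured here gives a reason for this step.

The compounds shown leave open whether an ethyl, a hydroxyl or a fluorine on this ring carbon would give a lower or a higher number than methyl or hydrogen. Going by these compounds, it also remains open whether adding a methyl to a saturated ring carbon of the core of compound 3 or compound 1 would produce a step of similar size.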